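Swapping one non-aromatic ring on compound 2

The source may hold more compounds than are shown below. What is called first, only, known or untested is meant among the compounds shown, and "the series" means these compounds.

Compound 1 `COc1ncc(-c2cc3c(N4CCN(C)CC4)ncnc3s2)cc1NS(=O)(=O)c1ccc(F)cc1F`: 560 nM
Compound 2 `COc1ncc(-c2nc3c(N4CC(C)OC(C)C4)ncnc3s2)cc1NS(=O)(=O)c1ccc(F)cc1F`: 270 nM

Both numbers come from a functional assay on HGC-27 cells (Homo sapiens) for antiproliferative activity, read by MTT assay, with stated times of 72 h and 4 h (a lower number here means a stronger inhibitor, a higher number a weaker inhibitor), and compound 2 holds the lower of the two, with a gap to compound 1 that lies beyond the usual scatter. These two compounds differ in more than one place, so their gap cannot be pinned on any single change. Compound 3 `COc1ncc(-c2nc3c(N4CCC(OC)CC4)ncnc3s2)cc1NS(=O)(=O)c1ccc(F)cc1F` has 4-methoxypiperidin-1-yl in place of 2,6-dimethylmorpholin-4-yl on an aromatic carbon and is otherwise the same as compound 2. Among the measured compounds shown here, no measured pair shows what such a swap does in this assay and so only a small shift towards a higher number is expected. The estimated step of a 1.2-fold higher number from compound 2 to compound 3 (0.09 log units; within the scatter) is expected to stay within the scatter. Compound 3 is expected to give 330 nM (estimated range 120 nM to 900 nM).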

Compound 3, half-maximal inhibitory concentration: 74 nM
Compound 3: middle estimate off by 4.5-fold (0.65 log units), on the high side; the whole stated range lies above it.
By their numbers in this assay, from the lowest: compound 3; then compound 2; then compound 1.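

In this assay, putting 4-methoxypiperidin-1-yl in place of 2,6-dimethylmorpholin-4-yl on this aromatic carbon gives a 3.6-fold lower number from compound 2 to compound 3 (0.56 log units; beyond the scatter), so the choice of ring at this position matters. The two groups have the same count of heavy atoms and of hydrogen-bond acceptors, and the entering ring holds one hetero atom where the leaving ring holds two. A swap that keeps those counts can therefore still move the number beyond the scatter, and nothing at hand gives a reason for this step.

Compound 1 differs from both in more than one place, so it cannot say whether the lower number comes from the methoxy group or from the piperidine ring itself. An unsubstituted piperidine, or a piperidine carrying a hydroxyl or an amine in place of methoxy, would help separate the two.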